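Swapping the Amide for a Ketone on a Shared Core

The source may hold more compounds than are shown below. What is called first, only, known or untested is meant among the compounds shown, and "the series" means these compounds.

Of the compounds shown here, two built on one shared core have been tested in a functional assay on HOP-62 cells (Homo sapiens) for inhibition, read by sulforhodamine B assay, with a stated time of 48 h; on this read-out higher numbers stand for weaker inhibition of growth and lower numbers for stronger inhibition of growth. Compound 1 `N#C/C(=C\N1CCN(C(=O)c2ccco2)C1=S)C(=O)Nc1ccc(Cl)cc1` gives 25700 nM in this assay. Compound 2 `N#C/C(=C\N1CCN(C(=O)c2ccco2)C1=S)C(N)=O` gives 25600 nM in this assay. Going by the values given here, the single step between them, a 1.0-fold lower number from compound 1 to compound 2 (0.00 log units; within the scatter), shows that a large group at that position can be removed without a change in growth inhibition beyond the scatter. Compound 2 and compound 1 therefore stand together, their two numbers within the scatter of each other, with nothing to set one above the other.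

Compound 3 `N#C/C(=C\N1CCN(C(=O)c2ccco2)C1=S)C(=O)c1ccccc1` takes compound 2 one step further: phenyl in place of amino on a carbonyl carbon, so that the carbamoyl becomes a benzoyl. Among the compounds with values here, no measured step touches this exact change. Within the data shown here, the only step on record, from compound 1 to compound 2, altered the same end of the molecule and left the number unchanged, which gives no reason to expect a shift here either. Compound 3 is therefore expected to sit close to compound 2, with an estimated step of a 1.0-fold lower number from compound 2 to compound 3 (0.01 log units; within the scatter) in this assay. The estimate for compound 3 is 25000 nM, within a range from 8000 nM to 80000 nM.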

Compound 3, concentration for 50% growth inhibition: 22000 nM
Compound 3: the middle estimate sits 1.1-fold (0.06 log units) above what was measured, within the range that was stated.
By their numbers in this assay, from the lowest: compounds 3, 2 and 1 (each within the scatter of the next).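

Putting phenyl in place of amino on a carbonyl carbon, so that carbamoyl becomes benzoyl, takes away the nitrogen and its hydrogen-bond donor and adds a six-membered aromatic ring, yet in this assay the result is a 1.2-fold lower number from compound 2 to compound 3 (0.07 log units; within the scatter). The comparison with the larger (4-chlorophenyl)amino group reads a 1.2-fold lower number from compound 1 to compound 3 (0.07 log units; within the scatter), so this nitrogen is now shown to be dispensable at this level of growth inhibition, which the earlier pair could not show, as both of its compounds kept it. Amino, (4-chlorophenyl)amino and phenyl on this carbonyl carbon therefore cannot be told apart in this cell line, and no separate measurement is available to explain this similarity.

From the compounds shown here alone, whether a carboxylic acid, a methoxy group or a longer alkyl chain on the same carbonyl carbon would move the number beyond the scatter remains open. Also open, going by these compounds, is how much the rest of the shared core contributes, as all three compounds carry it unchanged and only this one end of the molecule has been varied.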